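The source may report more compounds than this note shows. Statements on the series, on what has been measured and on what is new or still open speak of the compounds shown alone.

Measured so far in an ADME assay on Ava5 cells (Homo sapiens) for cytotoxicity; on this read-out lower numbers stand for higher toxicity in this test and higher numbers for lower toxicity in this test:
Compound 1 `NC(=S)Nc1cccc(OCCCCCOc2ccc(F)cc2)c1`, giving 5000 nM.
Compound 2 `CCN(CC)c1ccc(OCCCCCOc2cccc(NC(N)=S)c2)cc1`, which in this assay reaches only a limit, > 50000 nM, and not a number.

Within the data shown here, compound 1 stands at the only number given in this assay; the one further value shown is a limit. Among the measured compounds shown here, the step from compound 1 to compound 2 is an at least 10-fold higher number from compound 1 to compound 2 (1.00 log units; beyond the scatter), and this is the single measured step available, resting on (the limit of > 50000 nM in this assay, at which 1 of the 2 values shown sits).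

Compound 3 `NC(=S)Nc1cccc(OCCCCCOc2ccccn2)c1` is not yet measured. It differs from compound 1 in that (pyridin-2-yl in place of 4-fluorophenyl on an oxygen on a saturated carbon). For the measured compounds named here, no measured step exchanges one aromatic ring for another; the only step, from compound 1 to compound 2, alters a substituent on the ring that is here replaced, and it moved the number upward. That step therefore bears on the present change only loosely, and it gives no direction for the ring swap itself. Compound 3 is accordingly expected to sit close to compound 1 in this assay, with the step of a 1.4-fold higher number from compound 1 to compound 3 (0.15 log units; within the scatter) estimated to be small and within the scatter. For compound 3 the estimate is 7000 nM, with a range from 2500 nM to 30000 nM.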

Compound 3, half-maximal cytotoxic concentration: > 50000 nM
Compound 3 gave a limit, no number (the forecaster's own chance of this, stated with the estimate: 20%); middle value at least 7.1-fold (0.85 log units) from the limit.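

The exchange of the whole aromatic ring on an oxygen on a saturated carbon, pyridin-2-yl in place of 4-fluorophenyl, also shifts the read-out in this assay, with an at least 10-fold higher number from compound 1 to compound 3 (1.00 log units; beyond the scatter). The earlier compounds had shown only a change of substituent on this ring, so this is the first sign that replacing the ring itself matters here, and the ring enters with one hetero atom and no substituent at all. Compound 3 ends at a limit of the assay and not at a number, as compound 2 did, which leaves compound 1 as the only compound with a number, and how far each step truly reaches, or which of the two is larger, cannot be told: the limit of > 50000 nM in this assay, at which 2 of the 3 values shown sit.

The compounds shown leave open whether an unsubstituted phenyl in this place would stay with compound 1 or go with compound 3, and whether a pyrimidine ring would behave as pyridin-2-yl does. They also leave open whether a shorter or longer chain than that of compound 1 would change the read-out with either ring attached.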